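Replacing the aryl sulfonyl on the ring nitrogen

This account rests on a few compounds, and the source may have more. Where it says the series, first, only, none or still open, it means among the compounds named here.

Among the measured compounds shown here, compound 1 `Cc1ccc(S(=O)(=O)n2cnc3c(N4CCN(c5ccc(C(F)(F)F)cc5)CC4)ncnc32)cc1` is the lower of the two numbers so far: in a functional assay on HCT-116 cells (Homo sapiens) for cytotoxicity, read by sulforhodamine B assay, with a stated time of 72 h (a higher number here means a weaker inhibitor, a lower number a stronger inhibitor), compound 1 gives 4500 nM, while compound 2 `Cc1ccc(S(=O)(=O)n2cnc3c(N4CCC(C)CC4)ncnc32)cc1` gives 14600 nM, a gap beyond the scatter. Compound 3 `CCOC(=O)Cn1cnc2c(N3CCN(c4ccc(C(F)(F)F)cc4)CC3)ncnc21` keeps the core and the arylpiperazine of compound 1 and changes only the group on the ring nitrogen: (ethoxycarbonyl)methyl in place of (4-methylphenyl)sulfonyl on an aromatic nitrogen. For the measured compounds named here, no measured pair shows this exchange. A modest weakening is expected, so the step from compound 1 to compound 3 is estimated at a 1.8-fold higher number from compound 1 to compound 3 (0.25 log units; within the scatter). For compound 3 the expected value is 8000 nM, with a range of 2500 nM to 25000 nM.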

Compound 3, half-maximal inhibitory concentration: 72400 nM
The estimate for compound 3 lay 9.1-fold (0.96 log units) below the measured number, outside the stated range (above it).
By their numbers in this assay, from the lowest: compound 1; then compound 2; then compound 3.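

In this assay, with the arylpiperazine and core unchanged, (ethoxycarbonyl)methyl in place of (4-methylphenyl)sulfonyl on the aromatic nitrogen gives a 16-fold higher number from compound 1 to compound 3 (1.21 log units; beyond the scatter) and is a large step. Among the compounds shown here, this is the first reading of this position, and the group on the ring nitrogen strongly sets the number. Both groups count the same hydrogen-bond acceptors, so that count does not track the step, and nothing measured here explains it.

Still open, from the compounds shown here alone, is whether the sulfonyl or the aromatic ring of the departing group carries the effect. A methanesulfonyl or a benzyl group on the same nitrogen would separate the two.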